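From 4-Methoxyphenyl to 3-Fluorophenyl in Compound 3

This account rests on a few compounds, and the source may have more. Where it says the series, first, only, none or still open, it means among the compounds named here.

In a functional assay on KYSE-410 cells (Homo sapiens) for antiproliferative activity, read by MTT assay, with a stated time of 72 h (a lower number here means a stronger inhibitor, a higher number a weaker inhibitor), compound 1 `O=C(Nc1cccc(F)c1)c1cc(=O)[nH]c2cc(Br)ccc12`, which carries a bromo group, gives 7300 nM. Compound 3 `COc1ccc(-c2ccc3c(C(=O)Nc4cccc(F)c4)cc(=O)[nH]c3c2)cc1` gives 18000 nM, the higher of the two actual numbers and so the weaker result. Compound 2 `CC(=O)c1ccc(-c2ccc3c(C(=O)Nc4cccc(F)c4)cc(=O)[nH]c3c2)cc1` gives > 20000 nM, which is a limit of the assay and not a number.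

Compound 4 `O=C(Nc1cccc(F)c1)c1cc(=O)[nH]c2cc(-c3cccc(F)c3)ccc12` is not yet measured. It differs from compound 3 in one place, with 3-fluorophenyl in place of 4-methoxyphenyl on an aromatic carbon.

Two kinds of measured step bear on this change. Putting a substituted phenyl in place of bromo raised the number modestly, with a 2.5-fold higher number from compound 1 to compound 3 (0.39 log units; beyond the scatter) and an at least 2.7-fold higher number from compound 1 to compound 2 (0.43 log units; beyond the scatter). Changing the group on that phenyl, methoxy in place of acetyl, gave an at least 1.1-fold lower number from compound 2 to compound 3 (0.04 log units; that floor lies within the scatter), whose floor lies within the scatter. Compound 4 also has a substituted phenyl in place of bromo, as does compound 3 at 18000 nM, so no step beyond the scatter is expected. The expected change is a 1.3-fold lower number from compound 3 to compound 4 (0.11 log units; within the scatter). Compound 4 is estimated at 14000 nM, with an expected range from 7000 nM to 20000 nM.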

Compound 4, half-maximal inhibitory concentration: 10900 nM
Beside the measured number, compound 4's estimate is 1.3-fold (0.11 log units) above it; measured number inside the range.
By their numbers in this assay, from the lowest: compounds 1, 4 and 3 (each within the scatter of the next, the first and the last beyond it). At a limit, above all of these: compound 2.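

In this assay, 3-fluorophenyl in place of 4-methoxyphenyl gives a 1.7-fold lower number from compound 3 to compound 4 (0.22 log units; within the scatter), so this exchange cannot be told apart from the ordinary scatter of repeat measurements. Unlike the two earlier substituted phenyl groups, 3-fluorophenyl in place of bromo gives a 1.5-fold higher number from compound 1 to compound 4 (0.17 log units; within the scatter), so a substituted phenyl at this position does not always move the number beyond the scatter, although compounds 2 and 3 show that it can. With 3-fluorophenyl in place of 4-acetylphenyl, the result is an at least 1.8-fold lower number from compound 2 to compound 4 (0.26 log units; that floor lies within the scatter), which is only a floor, as the starting value there is a limit and not a number: the limit of > 20000 nM in this assay, at which 1 of the 4 values shown sits.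

The compounds shown leave open how a phenyl bearing an amine or a carboxylic acid would behave at this position. Compound 1 gives 7300 nM, and they also leave open whether any group here can give a clearly lower number.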